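Iodo to tert-butyl on urea and amide analogues

The source may hold more compounds than are shown below. What is called first, only, known or untested is meant among the compounds shown, and "the series" means these compounds.

Compound 1 `O=C(NCCCCl)Nc1ccc(I)cc1` and compound 3 `O=C(CCCCl)Nc1ccc(I)cc1` differ in their cores by 3-chloropropyl in place of (3-chloropropyl)amino on a carbonyl carbon. In a functional assay on M21 cells (Homo sapiens) for antiproliferative activity, with a stated time of 48 h (on this read-out lower numbers stand for stronger inhibition and higher numbers for weaker inhibition), compound 1 gives > 100000 nM, a limit of the assay. Compound 3 gives > 100000 nM in this assay, likewise a limit. Compound 2 `CC(C)(C)c1ccc(NC(=O)NCCCCl)cc1` carries tert-butyl in place of iodo on an aromatic carbon, and in this assay compound 2 gives 35000 nM, so that an at least 2.8-fold lower number from compound 1 to compound 2 (0.45 log units; beyond the scatter); the readable size is bounded by the limit of > 100000 nM in this assay, at which 2 of the 3 values shown sit. Compound 4 `CC(C)(C)c1ccc(NC(=O)CCCCl)cc1` carries the same kind of change, (tert-butyl in place of iodo on an aromatic carbon), with the place differing only in being para to a group of 7 heavy atoms rather than 8. Since compound 3 sits at the limit, as > 100000 nM shows, the step to compound 4 is expected to be roughly an at least 1.6-fold lower number from compound 3 to compound 4 (0.22 log units; that floor lies within the scatter). Compound 4 is expected to give about 60000 nM in this assay, between 15000 nM and 300000 nM.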

Compound 4, half-maximal inhibitory concentration: > 100000 nM
Compound 4: a limit, no number; the forecaster's own chance of this, stated with the estimate: 40%; middle value at least 1.6-fold (0.22 log units) from the limit.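

In this assay compound 4 gives > 100000 nM, a limit and not a number, and the steps joining two limits cannot be read: the limit of > 100000 nM in this assay, at which 3 of the 4 values shown sit. On these data alone, the tert-butyl for iodo change gives an at least 2.8-fold lower number from compound 1 to compound 2 (0.45 log units; beyond the scatter) on the core of compound 1, but on the core of compound 3 it yields no readable value, so its size there remains unknown and no loss of the effect can be measured. With tert-butyl held constant, the change of core gives an at least 2.8-fold higher number from compound 2 to compound 4 (0.45 log units; beyond the scatter), which shows that the readable value of compound 2 does not carry over to the core of compound 3.

Open, as far as these compounds go, is whether an amine or a carboxylic acid on that aromatic carbon would give a readable value on the core of compound 3. Also open, from the compounds shown here alone, is how a longer chain in place of 3-chloropropyl would read on either core.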